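Notes on the aryl exchange from compound 3 to compound 4

This account rests on a few compounds, and the source may have more. Where it says the series, first, only, none or still open, it means among the compounds named here.

Three measured compounds share one core and differ only in the aryl group on a saturated chain carbon bound to an amine nitrogen in a ring. In an assay on FRT cells for positive allosteric modulation of Cystic fibrosis transmembrane conductance regulator variant N1303K (Homo sapiens), in the presence of a further agent that is not named here (a lower number here means that less compound is needed, a higher number that more compound is needed for the effect), compound 1 `COc1ccc2[nH]c3c(c2c1)CCNC31CCN(Cc2cc(F)cc(Cl)c2)CC1` gives 2500 nM. Compound 2 `COc1ccc2[nH]c3c(c2c1)CCNC31CCN(Cc2ccccc2Cl)CC1` gives 2200 nM in this assay. Compound 3 `COc1ccc2[nH]c3c(c2c1)CCNC31CCN(Cc2ccc(Br)c(F)c2)CC1` gives 1800 nM in this assay, the lowest of the three numbers, though its distance to the others lies within the scatter: a 1.2-fold lower number from compound 2 to compound 3 (0.09 log units; within the scatter) and a 1.4-fold lower number from compound 1 to compound 3 (0.14 log units; within the scatter). The remaining step, a 1.1-fold lower number from compound 1 to compound 2 (0.06 log units; within the scatter), is also within the scatter. Three different aryl groups at this place have thus given numbers that cannot be told apart.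

Compound 4 `COc1ccc2[nH]c3c(c2c1)CCNC31CCN(Cc2cc(F)c(F)cc2F)CC1` is not yet measured. It differs from compound 3 in one place: 2,4,5-trifluorophenyl in place of 4-bromo-3-fluorophenyl on a saturated chain carbon bound to an amine nitrogen in a ring. All three measured steps bear on this change, since each exchanges one aryl group for another at the same place, and none of them moved the number beyond the scatter. For compound 4 no step beyond the scatter is therefore expected in this assay. The step expected is a 1.1-fold higher number from compound 3 to compound 4 (0.05 log units; within the scatter). Compound 4 is estimated at 2000 nM in this assay, with a range from 900 nM to 4500 nM.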

Compound 4, half-maximal effective concentration: 600 nM
The estimate for compound 4 lay 3.3-fold (0.52 log units) above the measured number; the measured number lies below the stated range.
By their numbers in this assay, from the lowest: compound 4; then compounds 3, 2 and 1 (each within the scatter of the next).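

In this assay the aryl group on a saturated chain carbon bound to an amine nitrogen in a ring can move the number beyond the scatter after all: 2,4,5-trifluorophenyl brings a 3.0-fold lower number from compound 3 to compound 4 (0.48 log units; beyond the scatter) and a 3.7-fold lower number from compound 2 to compound 4 (0.56 log units; beyond the scatter) and a 4.2-fold lower number from compound 1 to compound 4 (0.62 log units; beyond the scatter) against the three earlier aryl groups. Those three groups, 4-bromo-3-fluorophenyl, 2-chlorophenyl and 3-chloro-5-fluorophenyl, could not be told apart, so this position is not indifferent to the aryl group, and compound 4 alone separates from the others, with the lowest number of the series. The exchange from compound 3 to compound 4 removes bromine and adds fluorine, but nothing available bears on why this aryl group behaves differently from the other three.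

Going by these compounds, it remains open whether all three fluorines of 2,4,5-trifluorophenyl are needed, or whether a difluorophenyl group would give a similar number in this assay. On these data alone, it is equally open whether the lower number survives with a pyridine ring in place of the benzene ring, or with a trifluoromethyl group on the aryl ring.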